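The source may hold more compounds than are shown below. What is called first, only, known or untested is meant among the compounds shown, and "the series" means these compounds.

Working notes on the series. Compound 1 `Cc1ccc(C2C(C#N)=C(N)N(c3ccc(S(N)(=O)=O)cc3)C3=C2CCCC3)cc1` gives 20% in a functional assay on Ehrlich cells (Mus musculus) for cytotoxicity, read by trypan blue exclusion, with a stated time of 2 h, tested at 10 ug/mL; on this read-out lower numbers stand for a weaker effect and higher numbers for a stronger effect at the one concentration tested. Compound 2 `COc1ccccc1C1C(C#N)=C(N)N(c2ccc(S(N)(=O)=O)cc2)C2=C1CCCC2` gives 30% in this assay, and the step of a number 10 percentage points higher from compound 1 to compound 2 (within the scatter) places compound 2 within the scatter of compound 1, so no ranking follows. Compound 3 `N#CC1=C(N)N(c2ccc(S(N)(=O)=O)cc2)C2=C(CCCC2)C1c1ccc([N+](=O)[O-])cc1` is not yet measured; it differs from compound 2 by 4-nitrophenyl in place of 2-methoxyphenyl on a saturated ring carbon. Going by the values given here, the only step touching this saturated ring carbon is a number 10 percentage points higher from compound 1 to compound 2 (within the scatter), which stayed within the scatter. A step of the size a number 5 percentage points lower from compound 2 to compound 3 (within the scatter) in this assay is therefore expected, with no direction beyond the scatter. For compound 3 the estimate is 25%, within 10% to 45%.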

Compound 3, a percentage reported as activity, at one concentration (the size of the read-out at that concentration, not a potency): 0%
Compound 3: middle estimate off by 25 percentage points, on the high side; measured number below the stated range.
By their numbers in this assay, from the lowest: compound 3; then compounds 1 and 2 (each within the scatter of the next).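

In this assay the group on this saturated ring carbon now makes a difference beyond the scatter: 4-nitrophenyl in place of 2-methoxyphenyl gives a number 30 percentage points lower from compound 2 to compound 3 (beyond the scatter). Nitro in place of methyl on the aromatic carbon gives a number 20 percentage points lower from compound 1 to compound 3 (beyond the scatter), so the aryl change alone moves the read-out, which the earlier step did not show. No evidence at hand accounts for this drop. Open, going by these compounds, is whether the drop belongs to nitro specifically or would also follow from an amine or a carboxylic acid in its place on the phenyl ring.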